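Halogenated Anilino Analogue Awaits Its Cell Potency

The source may report more compounds than this note shows. Statements on the series, on what has been measured and on what is new or still open speak of the compounds shown alone.

Among the compounds with values here, compound 1 `Cc1n[nH]c2ccc(-c3nc4cnc(N5CCN(C)CC5)cn4c3Nc3ccc(Br)cc3)cc12` is the only member of this small set with a number: in a functional assay on MV4-11 cells (Homo sapiens) for inhibition, with a stated time of 120 h (a higher number here means a weaker inhibitor, a lower number a stronger inhibitor), compound 1 gives 2600 nM. Compound 2 `COc1ccc(Nc2c(-c3ccc4[nH]nc(C)c4c3)nc3cnc(N4CCN(C)CC4)cn23)cc1` has no result in this assay, where compound 2 stands at "not determined" (no result reported), so its standing cannot be placed on the numbers shown. Compound 3 `Cc1n[nH]c2ccc(-c3nc4cnc(N5CCN(C)CC5)cn4c3Nc3ccc(F)cc3Br)cc12` differs from compound 2 by 2-bromo-4-fluorophenyl in place of 4-methoxyphenyl on a nitrogen on an aromatic ring. Within the data shown here, with no measured step between these compounds, neither the size nor the direction of the change can be inferred, and a shift beyond the scatter remains possible in either direction. Among the measured compounds shown here, the only anchor is compound 1, which in this assay gives 2600 nM. Compound 3 is therefore expected to fall near 2500 nM, within a range of 600 nM to 10000 nM.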

Compound 3, half-maximal inhibitory concentration: 3830 nM
For compound 3 the middle estimate is 1.5-fold (0.19 log units) below the measured one; measured number inside the range.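

In this assay, 2-bromo-4-fluorophenyl in place of 4-bromophenyl on the nitrogen gives a 1.5-fold higher number from compound 1 to compound 3 (0.17 log units; within the scatter) and so leaves the two groups unseparated, which gives this position its first readable comparison. Compound 2 has no number, so the change from 4-methoxyphenyl to 2-bromo-4-fluorophenyl cannot be read. From the compounds shown here alone, whether an amine or a carboxylic acid on this phenyl ring would move the number beyond the scatter remains open, as does the place of the 4-methoxyphenyl group. No evidence is available that bears on this result.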